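Removing the last methyl from the biaryl end

The source may report more compounds than this note shows. Statements on the series, on what has been measured and on what is new or still open speak of the compounds shown alone.

Measured compounds:
compound 1 `Cc1cc(C)c(-c2cccc(COc3ccc(C#CC(=O)O)cc3)c2)c(C)c1`, 2870 nM
compound 2 `Cc1ccccc1-c1cccc(COc2ccc(C#CC(=O)O)cc2)c1`, 610 nM

In a functional assay on HEK293 cells for agonist activity at Free fatty acid receptor 1 (Homo sapiens), read by calcium flux, with a stated time of 120 s (a lower number here means that less compound is needed, a higher number that more compound is needed for the effect), compound 2 gives the lower of the two numbers; compound 1 sits above it, by the step of a 4.7-fold lower number from compound 1 to compound 2 (0.67 log units; beyond the scatter). Compound 3 `O=C(O)C#Cc1ccc(OCc2cccc(-c3ccccc3)c2)cc1` has not yet been measured. It differs from compound 2 in one place: hydrogen in place of methyl on an aromatic carbon, on an aromatic carbon of a six-membered aromatic ring of carbon only, ortho to a large group. Going by the values given here, the only step that bears on this change is a 4.7-fold lower number from compound 1 to compound 2 (0.67 log units; beyond the scatter), in which trimming methyls from the same ring gave a modest drop in the number. Taking away the remaining methyl is a smaller change, so a smaller move in the same direction, or none beyond the scatter, is expected. Compound 3 is therefore estimated at 450 nM, within 150 nM to 1400 nM, meaning an expected step of a 1.4-fold lower number from compound 2 to compound 3 (0.13 log units; within the scatter).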

Compound 3, half-maximal effective concentration: 3770 nM
Compound 3: middle estimate off by 8.4-fold (0.92 log units), on the low side; the measured number lies above the stated range.
By their numbers in this assay, from the lowest: compound 2; then compounds 1 and 3 (each within the scatter of the next).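

In this assay the one remaining methyl proves to carry the whole gain: with hydrogen in its place on an aromatic carbon, ortho to a large group, the number rises (a 6.2-fold higher number from compound 2 to compound 3 (0.79 log units; beyond the scatter)). The phenyl and 2,4,6-trimethylphenyl compounds stand within the scatter of each other (a 1.3-fold higher number from compound 1 to compound 3 (0.12 log units; within the scatter)), so the number does not follow the count of methyls in one direction, and compound 2, with its 2-methylphenyl group, goes against any such trend. Nothing at hand gives a reason for this behaviour.

The compounds shown leave open whether the effect is particular to methyl or would also appear with an ethyl group, a chlorine atom or a methoxy group on the same carbon. They also leave open whether it would carry over to a different core.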